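The compounds below may be only part of what the source reports. "The series", "measured", "known", "first", "only" and "open" are said of these compounds alone.

Measured so far in a physicochemical assay for solubility, measured as kinetic solubility; on this read-out lower numbers stand for lower solubility and higher numbers for higher solubility:
compound 1 `Cc1cnc(NC(=O)c2cc(Oc3ccc(S(C)(=O)=O)cc3)c3cn(C)nc3c2)cn1` gives 454000 nM
compound 2 `Cc1cnc(NC(=O)c2cc(Oc3ccc(S(=O)(=O)C4CC4)cc3)c3cn(C)nc3c2)cn1` gives 73000 nM
compound 3 `Cc1cnc(NC(=O)c2cc(Oc3ccc(S(=O)(=O)N(C)C)cc3)c3cn(C)nc3c2)cn1` gives 134000 nM

The placing of compound 3 rests on two steps: a 1.8-fold higher number from compound 2 to compound 3 (0.26 log units; within the scatter) and a 3.4-fold lower number from compound 1 to compound 3 (0.53 log units; beyond the scatter) leave it level with compound 2 and clearly lower than compound 1 on these three numbers. Compound 4 `CNS(=O)(=O)c1ccc(Oc2cc(C(=O)Nc3cnc(C)cn3)cc3nn(C)cc23)cc1` follows from compound 3 through hydrogen in place of methyl on a sulfonamide nitrogen and reads as hydrogen in place of methyl on a sulfonamide nitrogen, so that dimethylamino becomes methylamino. Within the data shown here, no measured step makes this change on a sulfonamide nitrogen, so the evidence is indirect. The nearest steps are the changes on the sulfonyl sulfur: a 6.2-fold lower number from compound 1 to compound 2 (0.79 log units; beyond the scatter) and a 3.4-fold lower number from compound 1 to compound 3 (0.53 log units; beyond the scatter) are both modest, and neither predicts this change directly. A small rise in this assay is therefore expected, possibly within the scatter, as a partial move back toward compound 1 with its 454000 nM on the same read-out. The expected size of the move is a 1.4-fold higher number from compound 3 to compound 4 (0.15 log units; within the scatter) as an estimate only. The value for compound 4 is estimated at 190000 nM with an expected range from 80000 nM to 420000 nM in this assay for now.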

Compound 4, solubility: 27000 nM
For compound 4 the middle estimate is 7.0-fold (0.85 log units) above the measured one; the whole stated range lies above it.
By their numbers in this assay, from the lowest: compound 4; then compounds 2 and 3 (each within the scatter of the next); then compound 1.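

In this assay, the sulfonamide nitrogen proves sensitive to a minimal edit: hydrogen in place of methyl gives a 5.0-fold lower number from compound 3 to compound 4 (0.70 log units; beyond the scatter), a step beyond the scatter, so dimethylamino and methylamino cannot be treated as interchangeable on the sulfonyl sulfur. Methylamino also falls short of cyclopropyl, with a 2.7-fold lower number from compound 2 to compound 4 (0.43 log units; beyond the scatter), and far short of methyl, with a 17-fold lower number from compound 1 to compound 4 (1.23 log units; beyond the scatter), which leaves compound 4 with the lowest number of the four. The earlier compounds shown here showed only that replacing methyl on the sulfonyl sulfur lowered the number, with cyclopropyl and dimethylamino level within the scatter; compound 4 adds a clearly separate lowest level and shows that this change moves the number further from compound 1, not back toward it.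

Nothing in the data at hand accounts for the size of this step. Still open, going by these compounds, is whether the step follows the hydrogen on the sulfonamide nitrogen or the particular methylamino group, a question that an unsubstituted amino group, ethylamino or a cyclic amine such as morpholine on the sulfonyl sulfur would help to settle.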